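Replacing Cyano with 1H-benzimidazol-2-yl in Compound 2

A few compounds are considered here, and "the series" means these few. Any claim that something is new, unique, unknown or untested is made for them only; others in the source may bear on it.

In a functional assay on A549 cells (Homo sapiens) for cytotoxicity, read by resazurin assay, with a stated time of 72 h (on this read-out higher numbers stand for weaker inhibition and lower numbers for stronger inhibition), two compounds have been measured so far. Compound 1 (`N#Cc1cc(-c2ccccc2)n(-c2ccc(Br)cc2)c1N`) gives 4600 nM and compound 2 (`N#Cc1cc(-c2ccccc2)n(-c2nc3ccccc3[nH]2)c1N`) gives 12100 nM as the higher of the two numbers, a gap beyond the scatter of repeated measurements. Compound 2 thus shows the weaker inhibition of this pair. Compound 3 (`Nc1c(-c2nc3ccccc3[nH]2)cc(-c2ccccc2)n1-c1nc2ccccc2[nH]1`) carries 1H-benzimidazol-2-yl in place of the cyano of compound 2, on an aromatic carbon next to the ring atom that bears an amino group (1H-benzimidazol-2-yl in place of cyano on an aromatic carbon). Among the measured compounds shown here, no measured pair differs in one place only, so the data show nothing directly about such a change in this assay at this point. A modest move towards a lower number is expected, possibly no larger than the scatter (estimated a 1.6-fold lower number from compound 2 to compound 3 (0.21 log units; within the scatter)). Compound 3 is expected at 7500 nM with a wide estimated range (from 2500 nM to 25000 nM).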

Compound 3, half-maximal inhibitory concentration: 7700 nM
Compound 3: middle estimate off by 1.0-fold (0.01 log units), on the low side; the measured number falls inside the stated range.
By their numbers in this assay, from the lowest: compounds 1, 3 and 2 (each within the scatter of the next, the first and the last beyond it).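

In this assay, among the compounds shown here, the exchange of cyano for 1H-benzimidazol-2-yl gives the first direct reading at this aromatic carbon of the five-membered ring: a 1.6-fold lower number from compound 2 to compound 3 (0.20 log units; within the scatter), a step within the scatter. The position thus takes a group of 9 heavy atoms with two aromatic rings in place of one of 2 heavy atoms, and the number does not shift beyond the scatter, even though the triple bond is gone and a hydrogen-bond donor enters. Nothing available accounts for this outcome.

On these data alone, it remains open whether a carboxylic acid, a primary amide or an aminomethyl group on this carbon would give a number beyond the scatter from that of compound 2. Also open, as far as these compounds go, is whether the same exchange would give a similar step on compound 1.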